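Trimming the Long Chain of Compound 1

This account rests on a few compounds, and the source may have more. Where it says the series, first, only, none or still open, it means among the compounds named here.

In an ADME assay on L929 cells (Mus musculus, culture collection number NCTC 929) for cytotoxicity, read by MTT assay, with a stated time of 72 h (a lower number here means a stronger inhibitor, a higher number a weaker inhibitor), compound 1 (`CCCCCCCCCCCCCCCCc1c(O)cc(C)oc1=O`) gives 38200 nM, and compound 3 (`CCCCCCCNC(=O)c1c(O)cc(C)oc1=O`) gives 187000 nM. Compound 1 therefore holds the lower of the two actual numbers, and its gap to compound 3 lies beyond the usual scatter of repeated measurements. Compound 2 (`Cc1cc(O)c(C(=O)C2CCCCC2)c(=O)o1`) reads > 200000 nM, which is a limit of the assay and not a number.

The next compound to be tested is compound 4 (`CCCCCCCCCCCCc1c(O)cc(C)oc1=O`), which shortens the long chain of compound 1: hydrogen in place of butyl on a saturated chain carbon, ten or more bonds along the chain from an aromatic carbon. In words, this puts hydrogen in place of butyl on a saturated chain carbon, ten or more bonds along the chain from an aromatic carbon.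

For the measured compounds named here, no measured pair of compounds shows this change alone, so any forecast is uncertain. A modest move toward a higher, weaker number is expected in this assay, close to the scatter or slightly beyond it. The estimated change is a 1.4-fold higher number from compound 1 to compound 4 (0.16 log units; within the scatter). For compound 4 the estimated value is 55000 nM, with an expected range from 20000 nM to 140000 nM.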

Compound 4, half-maximal inhibitory concentration: 57200 nM
Beside the measured number, compound 4's estimate is 1.0-fold (0.02 log units) below it, and the stated range covers the measured number.
By their numbers in this assay, from the lowest: compounds 1 and 4 (each within the scatter of the next); then compound 3. At a limit, above all of these: compound 2.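

For the compounds shown here, this is the first measured step at this place on the long chain. In this assay, the change from butyl to hydrogen gives a 1.5-fold higher number from compound 1 to compound 4 (0.18 log units; within the scatter), so this shortening leaves no change that can be told apart from repeat-to-repeat variation. A single pair therefore shows that the cytotoxicity reading of compound 1 does not depend measurably on those last carbons of its chain, and none of the evidence at hand explains why.

One step cannot show how the number would respond to a much shorter chain, such as ethyl, or to a longer chain than that of compound 1. It also leaves open what would happen if an amine or a carboxylic acid stood on this saturated chain carbon in place of hydrogen.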